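A Bridged Bicyclic Amine in Place of the Methylpiperidine Tail

The compounds below may be only part of what the source reports. "The series", "measured", "known", "first", "only" and "open" are said of these compounds alone.

Compound 3 `COc1cc(C)c(S(=O)(=O)N(C)CCOCC(=O)N2CCN(CC3CCN(C)CC3)CC2)c(C)c1` gives 4.5 nM in an assay on HEK293 cells for displacement of a labelled ligand from B1 bradykinin receptor (Homo sapiens), read by scintillation counting (on this read-out lower numbers stand for stronger inhibition and higher numbers for weaker inhibition), the lowest of the three numbers measured. Compound 2 `COc1cc(C)c(S(=O)(=O)N(C)CCOCC(=O)N2CCC(C(C)(C)CN(C)C)CC2)c(C)c1` gives 10 nM, and compound 1 `COc1cc(C)c(S(=O)(=O)N(C)CCOCC(=O)N2CCN(CCN(C)C)CC2)c(C)c1` gives 106 nM. Among the measured compounds shown here, the only single-point step known is a 24-fold lower number from compound 1 to compound 3 (1.37 log units; beyond the scatter), which shows how far the number can move when the group on the amine nitrogen in the ring is exchanged. Compound 4 `COc1cc(C)c(S(=O)(=O)N(C)CCOCC(=O)N2CCN([C@H]3CN4CCC3CC4)CC2)c(C)c1` differs from compound 3 by a group of 8 heavy atoms (7 carbon, 1 nitrogen; 2 six-membered non-aromatic rings with 1 hetero atom each) in place of a group of 8 heavy atoms (7 carbon, 1 nitrogen; one six-membered non-aromatic ring with 1 hetero atom), on an amine nitrogen in a ring. For the measured compounds named here, no measured step covers this particular exchange of one saturated amine group for another, so only a modest change is anticipated. Compound 4 is expected to give 6 nM, within a range from 2 nM to 20 nM, which corresponds to a 1.3-fold higher number from compound 3 to compound 4 (0.12 log units; within the scatter), a step expected to fall within the scatter.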

Compound 4, inhibition constant: 34 nM
Beside the measured number, compound 4's estimate is 5.7-fold (0.75 log units) below it; measured number outside the range, above it.
By their numbers in this assay, from the lowest: compound 3; then compound 2; then compound 4; then compound 1.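

Holding the count of heavy atoms the same does not make the two saturated amine groups interchangeable on this amine nitrogen in a ring: the exchange gives a 7.6-fold higher number from compound 3 to compound 4 (0.88 log units; beyond the scatter). The group with two six-membered rings still compares well with the open-chain group, giving a 3.1-fold lower number from compound 1 to compound 4 (0.49 log units; beyond the scatter). So this position separates groups of equal atom count, and the ring arrangement matters here as well as the presence of a ring.

Nothing available explains why the two ring groups differ. Going by these compounds, it also remains open how a 1-methylpyrrolidin-3-yl group would behave on this nitrogen.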